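Cyclohexylamino in Place of Dimethylamino: Expected Cytotoxicity

A few compounds are considered here, and "the series" means these few. Any claim that something is new, unique, unknown or untested is made for them only; others in the source may bear on it.

Compound 1, `CNc1nc(N)nc2c1ncn2/C=C1/CC1(CO)CO`, gives 67000 nM in an ADME assay on BCBL1 cells (Homo sapiens) for cytotoxicity, with a stated time of 7 days; on this read-out lower numbers stand for higher toxicity in this test and higher numbers for lower toxicity in this test.
Compound 2, `C=CCOc1nc(N)nc2c1ncn2/C=C1/CC1(CO)CO`, reaches only the limit > 20000 nM in this assay.
Compound 3, `CN(C)c1nc(N)nc2c1ncn2/C=C1/CC1(CO)CO`, likewise reaches only the limit > 20000 nM in this assay.

Compound 3 thus stands at a limit rather than at a number, as described by the limit of > 20000 nM in this assay, at which 2 of the 3 values shown sit. Compound 4, `Nc1nc(NC2CCCCC2)c2ncn(/C=C3/CC3(CO)CO)c2n1`, differs from compound 3 by cyclohexylamino in place of dimethylamino on an aromatic carbon. The steps that could guide this change are a step that the limit leaves unreadable from compound 1 to compound 3 and a step that the two limits leave unreadable from compound 2 to compound 3, and a step that the limit leaves unreadable from compound 1 to compound 2 is equally unreadable. For the measured compounds named here, no measured step therefore sets a size or a direction. With compound 3 at a limit, the change is expected to be a step that the limit leaves unreadable from compound 3 to compound 4, no step beyond the scatter in this assay. Compound 4 is estimated at 30000 nM, within 10000 nM to 100000 nM.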

Compound 4, half-maximal cytotoxic concentration: > 20000 nM
Compound 4: only a limit was reported; the forecaster's own chance of this, stated with the estimate: 60%; the middle value does not contradict the limit.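

None of the steps from compound 1, compound 2 or compound 3 to compound 4 can be read, because compound 4 also reaches only a limit: the limit of > 20000 nM in this assay, at which 3 of the 4 values shown sit.

From the compounds shown here alone, whether the different groups on the shared core set compound 2, compound 3 and compound 4 apart in cytotoxicity stays open.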